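This account rests on a few compounds, and the source may have more. Where it says the series, first, only, none or still open, it means among the compounds named here.

In a functional assay on A549 cells (Homo sapiens) for antiproliferative activity, read by CCK-8 assay, with a stated time of 72 h (on this read-out lower numbers stand for stronger inhibition of growth and higher numbers for weaker inhibition of growth), compound 1 `CCC1C(=O)N(C)c2cnc(-n3ccc4cc(C(=O)NC(C)C)ccc43)nc2N1c1ccn(C)n1` gives 22000 nM, and compound 2 `CCC1C(=O)N(C)c2cnc(-n3ccc4cc(C(=O)NC)ccc43)nc2N1c1ccn(C)n1` gives 43100 nM. The two compounds share a core and differ only on the amide nitrogen, where methyl stands in place of isopropyl. The measured step is a 2.0-fold higher number from compound 1 to compound 2 (0.29 log units; within the scatter), so compound 2 stands level with compound 1 and neither can be ranked ahead of the other.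

Compound 3 `CCC1C(=O)N(C)c2cnc(-n3ccc4cc(F)ccc43)nc2N1c1ccn(C)n1` departs further from this pair: fluoro in place of methylcarbamoyl on an aromatic carbon. The amide itself is thus gone from compound 3. For the measured compounds named here, the one measured step bears on this only loosely, since it changes the group on the amide nitrogen and keeps the amide. Going by the values given here, no measured compound lacks the amide, so the data give no direction for this change. Among the compounds with values here, with only that small step to go on, no shift beyond the scatter is expected in this assay, though the uncertainty is wide. The estimated change is a 1.4-fold lower number from compound 2 to compound 3 (0.16 log units; within the scatter). For compound 3 the expected value is 30000 nM, with an estimated range of 9000 nM to 80000 nM.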

Compound 3, concentration for 50% growth inhibition: "not active" (no number reported)
The entry for compound 3 holds no number; there is nothing to compare the estimate with.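

In this assay, for the compounds shown here, compound 3 is recorded as "not active" with no number, so no step from compound 2 to compound 3 can be read. The compounds shown leave open how far growth inhibition changes when fluoro stands in place of methylcarbamoyl. No measurement shown offers an explanation for this result.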